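A nitro swap on a weakly active compound

The compounds below may be only part of what the source reports. "The series", "measured", "known", "first", "only" and "open" are said of these compounds alone.

In an ADME assay on A2780 cells (Homo sapiens) for inhibition, read by trypan blue exclusion, with a stated time of 72 h (on this read-out lower numbers stand for stronger inhibition of growth and higher numbers for weaker inhibition of growth), compound 2 `O=C(/C=C/c1ccccc1C(F)(F)F)c1ccccc1` gives 7.2 nM, while compound 3 `O=C(/C=C/c1ccccc1)c1ccccc1C(F)(F)F` gives 5800 nM in the same test. Compound 1 `O=C(/C=C/c1ccccc1)c1cccc(C(F)(F)F)c1` returns only a limit, > 20000 nM, and not a number. Compound 3 therefore holds the higher of the two real numbers, with a gap to compound 2 that lies well beyond the scatter.

Compound 4 `O=C(/C=C/c1ccccc1)c1ccccc1[N+](=O)[O-]` has nitro in place of trifluoromethyl on an aromatic carbon, ortho to a large group: nitro in place of trifluoromethyl on an aromatic carbon. Going by the values given here, no measured pair shows this swap, so the expectation in this assay is a change no larger than the scatter, in neither direction. The expected change is a 1.5-fold lower number from compound 3 to compound 4 (0.16 log units; within the scatter) in size. For compound 4 the estimated value is 4000 nM, with an expected range from 800 nM to 20000 nM in this test.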

Compound 4, concentration for 50% growth inhibition: 5800 nM
Compound 4: the middle estimate sits 1.5-fold (0.16 log units) below what was measured; low and high end bracket the measured number.
By their numbers in this assay, from the lowest: compound 2; then compounds 3 and 4 (each within the scatter of the next). At a limit, above all of these: compound 1.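

In this assay, putting nitro in place of trifluoromethyl gives no change at the digits printed from compound 3 to compound 4 (within the scatter), so on this aromatic carbon, ortho to a large group, the two groups cannot be told apart. Until now this position had shown only trifluoromethyl, so this is the first sign that a different group can sit there without moving the number.

As far as these compounds go, whether an amine or a carboxylic acid at this position would read the same remains open. Nothing shown here explains why these two groups give the same reading.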